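This account rests on a few compounds, and the source may have more. Where it says the series, first, only, none or still open, it means among the compounds named here.

Measured in an ADME assay on MT4 cells (Homo sapiens) for cytotoxicity, read by MTT assay, with a stated time of 4 days; a lower number here means that less compound is tolerated, a higher number that more compound is tolerated:
- compound 1, `COc1ccc(-c2cc(=O)c3cc(NC(C)=O)ccc3o2)cc1`: compound 1 gives 226000 nM
- compound 2, `CC(=O)Nc1ccc2oc(-c3ccc(F)cc3)cc(=O)c2c1`: compound 2 gives 203000 nM
- compound 3, `COc1ccc(-c2cc(=O)c3cc(N)ccc3o2)cc1`: compound 3 gives 241000 nM

Compound 3 stands apart from compound 1 only by a 1.1-fold higher number from compound 1 to compound 3 (0.03 log units; within the scatter), and its value and that of compound 2 lie within the usual scatter of one another; the three numbers sit together, with no separation that can be read as real.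

Compound 4, `Nc1ccc2oc(-c3ccc(F)cc3)cc(=O)c2c1`, has not yet been measured in this assay. It differs from compound 3 in one place: fluoro in place of methoxy on an aromatic carbon. The same change occurs once among the measured compounds, as a 1.1-fold lower number from compound 1 to compound 2 (0.05 log units; within the scatter), a flat step. Among the compounds with values here, no other measured pair bears on it. With a single relevant step, and that one within the scatter, the expectation for compound 4 in this assay is a number close to that of compound 3, with no step beyond the scatter in either direction. Compound 4 is therefore estimated at 220000 nM, in a range from 120000 nM to 400000 nM. This estimate amounts to an expected 1.1-fold lower number from compound 3 to compound 4 (0.04 log units; within the scatter).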

Compound 4, half-maximal cytotoxic concentration: 264000 nM
For compound 4 the middle estimate is 1.2-fold (0.08 log units) below the measured one; the range from low to high includes it.
By their numbers in this assay, from the lowest: compounds 2, 1, 3 and 4 (each within the scatter of the next).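

Working notes on the series: in this assay, fluoro in place of methoxy on the aromatic carbon para to a large group also stays flat with hydrogen rather than acetyl on the nitrogen, giving a 1.1-fold higher number from compound 3 to compound 4 (0.04 log units; within the scatter). The flat reading of this change therefore no longer rests on one pair: the same change on two cores in this assay, a 1.1-fold lower number (0.05 log units; within the scatter) from compound 1 to compound 2 and a 1.1-fold higher number (0.04 log units; within the scatter) from compound 3 to compound 4, 1.2-fold (0.09 log units) apart, within the scatter of two such steps. Hydrogen in place of acetyl is likewise flat with fluoro in place of methoxy, giving a 1.3-fold higher number from compound 2 to compound 4 (0.11 log units; within the scatter), so neither change shows any dependence on the other across these four compounds: the same change on two cores in this assay, a 1.1-fold higher number (0.03 log units; within the scatter) from compound 1 to compound 3 and a 1.3-fold higher number (0.11 log units; within the scatter) from compound 2 to compound 4, 1.2-fold (0.09 log units) apart, within the scatter of two such steps.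

From the compounds shown here alone, whether this position tolerates any substituent equally remains open, since a carboxylic acid, a dimethylamino group or a longer chain such as butoxy could still move the number. The compounds shown also leave open whether a larger acyl group or a sulfonyl group on the nitrogen would stay as flat in this assay.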